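The compounds below may be only part of what the source reports. "The series", "measured", "known", "first", "only" and "open" are said of these compounds alone.

Measured so far:
Compound 1 `CCOC(=O)CCO/N=C(/c1ccc(OC)c(OC)c1OC)c1cccc2ccccc12`: 15200 nM
Compound 2 `COc1ccc(C(O)(Cc2ccc(C)cc2)c2cccc3ccccc23)c(OC)c1OC`: > 20000 nM
Compound 3 `COc1ccc(C(OCc2ccccc2)c2cccc3ccccc23)c(OC)c1OC`: > 20000 nM

Among the compounds with values here, in a functional assay on MDA-MB-231 cells (Homo sapiens) for inhibition, read by sulforhodamine B assay, with a stated time of 48 h (on this read-out lower numbers stand for stronger inhibition and higher numbers for weaker inhibition), compound 1 gives 15200 nM, the only actual number among the three. Compound 2 reaches only a limit of the assay, > 20000 nM. Compound 3 likewise stops at a limit, > 20000 nM. Two of the three values therefore sit at the limit of > 20000 nM in this assay, at which 2 of the 3 values shown sit, and compound 1 is the sole point of reference.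

Compound 4 `CCOC(=O)/C=C/CO/N=C(/c1ccc(OC)c(OC)c1OC)c1cccc2ccccc12` differs from compound 1 in one place: 2-(ethoxycarbonyl)ethenyl in place of (ethoxycarbonyl)methyl on a saturated chain carbon bound to an oxygen on an unsaturated carbon, the change sitting on a saturated chain carbon bound to an oxygen on an unsaturated carbon. Within the data shown here, no measured pair shows such a step, so no direction can be read from the data. The estimate for compound 4 is 15000 nM, with a range of 6000 nM to 40000 nM, a step from compound 1 to compound 4 of a 1.0-fold lower number from compound 1 to compound 4 (0.01 log units; within the scatter), expected to stay within the usual scatter.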

Compound 4, half-maximal inhibitory concentration: > 20000 nM
Compound 4 was reported as a limit; the forecaster's own chance of this, stated with the estimate: 30%; middle value at least 1.3-fold (0.12 log units) from the limit.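

Within the data shown here, this is the first step read at this position: in this assay, 2-(ethoxycarbonyl)ethenyl in place of (ethoxycarbonyl)methyl on a saturated chain carbon bound to an oxygen on an unsaturated carbon gives an at least 1.3-fold higher number from compound 1 to compound 4 (0.11 log units; that floor lies within the scatter). On these data alone, the value of compound 4 is a limit of the assay, so the true size of this step stays unknown, and the change shows no gain in inhibition. Compound 1 remains the only compound with an actual number: the limit of > 20000 nM in this assay, at which 3 of the 4 values shown sit.

The compounds shown leave open how a carboxylic acid or an amine at the end of this chain would read. They also leave open whether any change here can give clearly stronger inhibition than compound 1.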